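The compounds below may be only part of what the source reports. "The series", "measured", "known", "first", "only" and "open" are said of these compounds alone.

Measured so far:
- compound 1 `Cc1oc(-c2ccc(Cl)cc2)nc1CN1CCC(C(=O)NCCCN2C[C@H](C)C[C@H](C)C2)CC1`: 11500 nM
- compound 2 `Cc1cccc(Cl)c1-c1nc(CN2CCC(C(=O)NCCCN3CCCC(C)C3)CC2)c(C)o1`: 16400 nM

In an ADME assay on Huh7.5.1 cells (Homo sapiens) for cytotoxicity, read by ATP content, with a stated time of 48 h (on this read-out lower numbers stand for higher toxicity in this test and higher numbers for lower toxicity in this test), compound 1 gives 11500 nM, the lowest of the two numbers, while compound 2 gives 16400 nM; the two values lie within the scatter of each other, so neither compound can be called more or less toxic than the other. Within the data shown here, no step between measured compounds is available.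

Compound 3 `Cc1cccc(C)c1-c1nc(CN2CCC(C(=O)NCCCN3C[C@H](C)C[C@H](C)C3)CC2)c(C)o1` is not yet measured. Compared with compound 1 it carries 2,6-dimethylphenyl in place of 4-chlorophenyl on an aromatic carbon. Without a measured step that speaks to this change, the expectation rests on the two values alone, and both sit close together. The step from compound 1 to compound 3 in this assay is therefore expected to be a 1.0-fold higher number from compound 1 to compound 3 (0.02 log units; within the scatter), none beyond the scatter in either direction. For compound 3 the estimated value in this assay is 12000 nM, with a range from 5000 nM to 30000 nM.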

Compound 3, half-maximal cytotoxic concentration: 21000 nM
Compound 3: the middle estimate sits 1.8-fold (0.24 log units) below what was measured, and the stated range covers the measured number.
By their numbers in this assay, from the lowest: compounds 1, 2 and 3 (each within the scatter of the next).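

In this assay, 2,6-dimethylphenyl in place of 4-chlorophenyl on this aromatic carbon gives a 1.8-fold higher number from compound 1 to compound 3 (0.26 log units; within the scatter) with the rest of the molecule unchanged. Among these compounds, this is the first comparison of compounds that differ in one place, and it shows that this exchange, which removes the chlorine and brings in two methyl groups, leaves the number within the usual scatter. Nothing measured here explains the size of this step.

The loss of the chlorine and the arrival of the methyl groups come together in this one step, so the compounds shown cannot separate their contributions. As far as these compounds go, it also remains open whether a phenyl ring carrying an amine or a carboxylic acid on this aromatic carbon would stay within the scatter of compound 1.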